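The source may hold more compounds than are shown below. What is called first, only, known or untested is meant among the compounds shown, and "the series" means these compounds.

In a functional assay on NCI-H1299 cells (Homo sapiens) for antiproliferative activity, read by CCK-8 assay, with a stated time of 72 h (a higher number here means a weaker inhibitor, a lower number a stronger inhibitor), compound 1 (`CCOc1cc(C(C)(C)C)ccc1C1=NC(c2ccc(Cl)cc2)C(c2ccc(Cl)cc2)N1C(=O)NCCCCCCCC(=O)NO`) gives 9060 nM and compound 2 (`CCOc1cc(C(C)(C)C)ccc1C1=NC(c2ccc(Cl)cc2)C(c2ccc(Cl)cc2)N1C(=O)NCCCCCC(=O)Nc1ccccc1N`) gives 19100 nM, so compound 2 holds the higher of the two numbers and is the weaker inhibitor of this pair.

Compound 3 (`CCOc1cc(C(C)(C)C)ccc1C1=NC(c2ccc(Cl)cc2)C(c2ccc(Cl)cc2)N1C(=O)NCCCCC(=O)Nc1ccccc1N`) keeps the (2-aminophenyl)carbamoyl group of compound 2 but on a shorter chain: (2-aminophenyl)carbamoyl in place of ((2-aminophenyl)carbamoyl)methyl on a saturated chain carbon, four bonds along the chain from an amide-type nitrogen. Put simply, (2-aminophenyl)carbamoyl stands in place of ((2-aminophenyl)carbamoyl)methyl on a saturated chain carbon, four bonds along the chain from an amide-type nitrogen.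

Going by the values given here, only one measured step offers any guidance, and it is modest: a 2.1-fold higher number from compound 1 to compound 2 (0.32 log units; beyond the scatter). Among the compounds with values here, that step exchanged 2-(hydroxycarbamoyl)ethyl for (2-aminophenyl)carbamoyl, so it changed the terminal group as well as the chain, and no measured pair isolates chain length alone. With so little evidence, the value of compound 2, 19100 nM, is the best starting point, and no change beyond the scatter is expected in this assay, in either direction. The expected change is a 1.0-fold higher number from compound 2 to compound 3 (0.02 log units; within the scatter). For compound 3 the estimated value is 20000 nM, with an expected range of 10000 nM to 40000 nM.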

Compound 3, half-maximal inhibitory concentration: 15600 nM
For compound 3 the middle estimate is 1.3-fold (0.11 log units) above the measured one; the range from low to high includes it.
By their numbers in this assay, from the lowest: compounds 1, 3 and 2 (each within the scatter of the next, the first and the last beyond it).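

In this assay, going by these compounds alone, compound 3 gives the first look at chain length alone, with the (2-aminophenyl)carbamoyl end group kept in both compounds. Going from 2-((2-aminophenyl)carbamoyl)ethyl to ((2-aminophenyl)carbamoyl)methyl at this position leaves the reading within the scatter (a 1.2-fold lower number from compound 2 to compound 3 (0.09 log units; within the scatter)), so this shortening has no clear effect on the number. Compound 3 also stays within the scatter of the hydroxycarbamoyl compound (a 1.7-fold higher number from compound 1 to compound 3 (0.24 log units; within the scatter)), even though that step changes both the end group and the chain, which means the gap between compound 1 and compound 2 does not show a firm preference for either end group; nothing measured here explains these readings.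

As far as these compounds go, whether a longer chain or a much shorter chain carrying (2-aminophenyl)carbamoyl would move the number beyond the scatter remains open. So does the effect of the end group on a chain of matched length, and whether a carboxylic acid or a simple amine at the chain end would read differently from the hydroxycarbamoyl and (2-aminophenyl)carbamoyl groups.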